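A few compounds are considered here, and "the series" means these few. Any claim that something is new, unique, unknown or untested is made for them only; others in the source may bear on it.

Measured so far:
- compound 1 `NC(=S)N(O)CC1=Cc2cc(Oc3ccccc3)ccc2OC1` — 180 nM
- compound 2 `CCCCNC(=O)N(O)CC1=Cc2cc(Oc3ccccc3)ccc2OC1` — 65 nM

Within the data shown here, in an assay (Cavia porcellus) for inhibition of Polyunsaturated fatty acid 5-lipoxygenase (Homo sapiens) (a higher number here means a weaker inhibitor, a lower number a stronger inhibitor), compound 2 gives the lowest of the two numbers; its only neighbour is compound 1, which gives 180 nM, and the step of a 2.8-fold lower number from compound 1 to compound 2 (0.44 log units; beyond the scatter) lies beyond the scatter, so compound 2 is the stronger inhibitor of the two.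

Compound 3 `O=C(NCc1ccccc1)N(O)CC1=Cc2cc(Oc3ccccc3)ccc2OC1` is not yet measured. It differs from compound 2 in one place: phenyl in place of propyl on a saturated chain carbon bound to an amide-type nitrogen, so that butyl on the urea nitrogen becomes benzyl. Among the measured compounds shown here, the one measured step, a 2.8-fold lower number from compound 1 to compound 2 (0.44 log units; beyond the scatter), changed a different part of that nitrogen's substituent, a thiourea group against a butyl urea, and so does not speak directly to a propyl-to-phenyl exchange. For the measured compounds named here, no step here tells how such an exchange moves the numbers in this assay, so a change within the scatter is expected; the estimated step of a 1.1-fold higher number from compound 2 to compound 3 (0.03 log units; within the scatter) reflects that. Compound 3 is therefore estimated at 70 nM, within 25 nM to 200 nM.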

Compound 3, half-maximal inhibitory concentration: 440 nM
The estimate for compound 3 lay 6.3-fold (0.80 log units) below the measured number, outside the stated range (above it).
By their numbers in this assay, from the lowest: compound 2; then compound 1; then compound 3.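

In this assay, the end of the butyl chain on the urea nitrogen turns out to matter: phenyl in place of propyl, which makes butyl into benzyl, gives a 6.8-fold higher number from compound 2 to compound 3 (0.83 log units; beyond the scatter) and so weakens inhibition. The other comparison shows a 2.4-fold higher number from compound 1 to compound 3 (0.39 log units; beyond the scatter) while compound 2 sits on the lower side of compound 1, so a larger group on this nitrogen does not by itself bring the number down, since butyl does and benzyl does not. Nothing available explains why the two groups differ.

The compounds shown leave open whether the loss follows the aromatic ring itself or simply the greater size of the group. Cyclohexylmethyl or a longer chain such as hexyl on the same nitrogen would separate those two readings.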